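Bromo to Methoxy Swap and Toxicity on Vero Cells

This account rests on a few compounds, and the source may have more. Where it says the series, first, only, none or still open, it means among the compounds named here.

In an ADME assay on Vero cells (Chlorocebus sabaeus) for cytotoxicity, read by neutral red uptake (on this read-out lower numbers stand for higher toxicity in this test and higher numbers for lower toxicity in this test), the three measured compounds give only limits of the assay, not numbers:
Compound 1, `CC1(C)CC(=O)C(=C/C=C/c2ccc(Br)cc2)C(=O)C1`, stands at the limit > 14.3 uM.
Compound 2, `COc1ccc(/C=C/C=C2C(=O)CC(C)(C)CC2=O)cc1`, stands at the limit > 16.7 uM.
Compound 3, `O=C1CCC(=O)C1=C/C=C/c1ccc(Br)cc1`, stands at the limit > 16.3 uM.

Compound 1 and compound 2 differ by methoxy in place of bromo on an aromatic carbon, and the step in this assay is a step that the two limits leave unreadable from compound 1 to compound 2; with the limit of > 14.3 uM in this assay, at which 1 of the 3 values shown sits, and the limit of > 16.7 uM in this assay, at which 1 of the 3 values shown sits, its size cannot be read. The difference between the core of compound 1 and the core of compound 3 is not broken down here. Compound 4, `COc1ccc(/C=C/C=C2C(=O)CCC2=O)cc1`, is not yet measured and differs from compound 3 by methoxy in place of bromo on an aromatic carbon, the same change at the same place. The step from compound 3 to compound 4 in this assay is expected to be a step that the limit leaves unreadable from compound 3 to compound 4, resting on compound 3 at the limit of > 16.3 uM in this assay, at which 1 of the 3 values shown sits, and on the unreadable earlier step. Compound 4 is expected to give 25 uM, between 10 uM and 60 uM, most likely again reported only as a limit.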

Compound 4, half-maximal toxic concentration: > 19.6 uM
Compound 4: no number, only a limit (the forecaster's own chance of this, stated with the estimate: 80%); the middle value does not contradict the limit.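

Compound 3 and compound 4 give only limits in this assay, as do compound 1 and compound 2, and the methoxy-for-bromo step cannot be read in either pair. Left open are the half-maximal toxic concentrations of all four compounds and whether this swap changes them at all.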